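The source may hold more compounds than are shown below. What is called first, only, known or untested is meant among the compounds shown, and "the series" means these compounds.

Compound 1 `CCCCC(=O)N(Cc1ccc(OC)c(O)c1)c1cc(OC)c(OC)c(OC)c1`: 170 nM
Compound 2 `COc1ccc(N(Cc2cc(OC)c(OC)c(OC)c2)C(=O)CCl)cc1O`: 22500 nM

In a functional assay on HCT-116 cells (Homo sapiens) for inhibition, read by MTT assay, with a stated time of 48 h (on this read-out lower numbers stand for stronger inhibition and higher numbers for weaker inhibition), compound 1 gives 170 nM, the lowest of the two numbers, while compound 2 gives 22500 nM, a gap beyond the scatter. Compound 3 `CCC(=O)N(Cc1ccc(OC)c(O)c1)c1cc(OC)c(OC)c(OC)c1` has not yet been measured. It differs from compound 1 by hydrogen in place of ethyl on a saturated chain carbon, two bonds along the chain from a carbonyl carbon. Going by the values given here, no step between measured compounds mirrors this change, so the expectation rests on compound 1 alone. Because compound 1 stands at 170 nM, a modest rise in the number is expected for compound 3, a 2.6-fold higher number from compound 1 to compound 3 (0.42 log units; beyond the scatter). Compound 3 is accordingly estimated at 450 nM, with a range from 150 nM to 1500 nM.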

Compound 3, half-maximal inhibitory concentration: 61 nM
Estimate against measurement, compound 3: 7.4-fold (0.87 log units) above; measured number below the stated range.
By their numbers in this assay, from the lowest: compound 3; then compound 1; then compound 2.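

In this assay, hydrogen in place of ethyl on a saturated chain carbon, two bonds along the chain from a carbonyl carbon, gives a 2.8-fold lower number from compound 1 to compound 3 (0.45 log units; beyond the scatter). The position therefore accepts propanoyl in place of the longer acyl group of compound 1 without any loss, and the outer ethyl is not needed for activity at this level. Nothing measured here gives a reason for this step.

One step sets no trend with chain length. As far as these compounds go, whether an acetyl group, or an amine or a carboxylic acid at the end of the chain, would lower or raise the number remains open.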